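This account rests on a few compounds, and the source may have more. Where it says the series, first, only, none or still open, it means among the compounds named here.

Three compounds have been measured in a functional assay on the whole organism with Mus musculus as the target, in the maximal electroshock model, with a stated time of 120 min; on this read-out higher numbers stand for an effect only at larger amounts of compound and lower numbers for an effect already at smaller amounts:

Compound 1, `CCCc1cccc(N2CCNCC2)n1`, gives 10 mg/kg.
Compound 2, `CCCCc1cccc(N2CCNCC2)n1`, gives 30 mg/kg.
Compound 3, `CCCCCc1cccc(N2CCNCC2)n1`, gives 10 mg/kg.

Going by the values given here, on these numbers compound 3 stands level with compound 1, and the two together give the lowest numbers of the three; the step of a 3.0-fold lower number from compound 2 to compound 3 (0.48 log units; beyond the scatter) is the only one that separates compound 3 from another compound beyond the scatter, while no change at the digits printed from compound 1 to compound 3 (within the scatter).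

Compound 4, `c1cc(CC2CCCCC2)nc(N2CCNCC2)c1`, has not yet been measured. It differs from compound 3 in one place: cyclohexyl in place of butyl on a saturated chain carbon bound to an aromatic carbon. The three measured steps all change the length of the chain rather than closing it into a ring, so none of them tests this change directly. They do show how much the read-out moved when the chain was altered: a 3.0-fold higher number from compound 1 to compound 2 (0.48 log units; beyond the scatter), and a 3.0-fold lower number from compound 2 to compound 3 (0.48 log units; beyond the scatter), with no change at the digits printed from compound 1 to compound 3 (within the scatter). The numbers thus stayed within a modest band across the three chain lengths.

On that basis the step of no change at the digits printed from compound 3 to compound 4 (within the scatter) is expected to be small, with no clear direction, and may well stay within the scatter. The estimate for compound 4 is 10 mg/kg, with a range from 5 mg/kg to 30 mg/kg.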

Compound 4, minimum effective dose: 100 mg/kg
Estimate against measurement, compound 4: 10-fold (1.00 log units) below; measured number above the stated range.
By their numbers in this assay, from the lowest: compounds 1 and 3 (each within the scatter of the next); then compound 2; then compound 4.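

In this assay, putting cyclohexyl in place of butyl on a saturated chain carbon bound to an aromatic carbon moved the number further than any change of chain length had: a 10-fold higher number from compound 3 to compound 4 (1.00 log units; beyond the scatter). The two other comparisons point the same way, with a 10-fold higher number from compound 1 to compound 4 (1.00 log units; beyond the scatter) and, even against the highest of the open-chain numbers, a 3.3-fold higher number from compound 2 to compound 4 (0.52 log units; beyond the scatter). So this position does not treat all carbon-only groups alike: the open chains stayed within a narrow band, while the group bearing a six-membered ring gave the highest number of the four, meaning an effect only at a larger dose.

No measurement here bears on why the ring raises the number. Cyclohexyl brings both a ring and more carbon atoms than butyl, so this single step cannot separate the two, and a cyclopropyl or phenyl group in the same place would help show whether the ring itself or the size of the group counts.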